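Amide aryl variation on the shared core

This account rests on a few compounds, and the source may have more. Where it says the series, first, only, none or still open, it means among the compounds named here.

Among the measured compounds shown here, compound 2 `COc1ccc(C(=O)Nc2cccc(-c3oc4cc(-c5ccc(F)cc5)ccc4c(=O)c3O)c2)c(F)c1` gives 15300 nM in a functional assay on GTL 16 cells for antiproliferative activity against GTL 16 cell line (Homo sapiens), read by CCK-8 assay, with a stated time of 72 h (a higher number here means a weaker inhibitor, a lower number a stronger inhibitor), the higher of the two numbers measured so far; its nearest neighbour is compound 1 `Cc1cccc(C(=O)Nc2cccc(-c3oc4cc(-c5ccc(F)cc5)ccc4c(=O)c3O)c2)c1`, which gives 10900 nM in this assay. For the measured compounds named here, the one step between them, a 1.4-fold higher number from compound 1 to compound 2 (0.15 log units; within the scatter), changes only the aryl group on the carbonyl carbon and stays within the scatter. Compound 3 `O=C(Nc1cccc(-c2oc3cc(-c4ccc(F)cc4)ccc3c(=O)c2O)c1)c1ccc(Cl)nc1` is not yet measured; it differs from compound 2 by 6-chloropyridin-3-yl in place of 2-fluoro-4-methoxyphenyl on a carbonyl carbon. Going by the values given here, the only measured step that bears on this change is the step from compound 1 to compound 2, where a different aryl group entered at the same carbonyl carbon, and that step was within the scatter. On this basis no step beyond the scatter is expected in this assay from compound 2 to compound 3, and the expected move is a 1.2-fold lower number from compound 2 to compound 3 (0.07 log units; within the scatter). Among the compounds with values here, compound 3 is estimated at 13000 nM in this assay, with a range from 5000 nM to 35000 nM, the width reflecting that a single within-scatter step is the only guide.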

Compound 3, half-maximal inhibitory concentration: 7520 nM
For compound 3 the middle estimate is 1.7-fold (0.24 log units) above the measured one; the range from low to high includes it.
By their numbers in this assay, from the lowest: compounds 3, 1 and 2 (each within the scatter of the next, the first and the last beyond it).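

Among the compounds shown here, at the aryl group on the carbonyl carbon, this assay now gives a first step beyond the scatter, a 2.0-fold lower number from compound 2 to compound 3 (0.31 log units; beyond the scatter), with 6-chloropyridin-3-yl in place of 2-fluoro-4-methoxyphenyl, so the choice of aryl group at this position can change the number, though only modestly so far. The same entering group in place of 3-methylphenyl gives a 1.4-fold lower number from compound 1 to compound 3 (0.16 log units; within the scatter), which stays within the scatter, so 6-chloropyridin-3-yl is separated from 2-fluoro-4-methoxyphenyl but not from 3-methylphenyl. No measurement available here explains the difference between these aryl groups.

The exchange between compound 2 and compound 3 alters the ring nitrogen, chlorine, fluorine and methoxy groups together, so the compounds shown do not assign the step to any one of them. On these data alone, it also remains open whether a larger move would follow from a different kind of group on the carbonyl carbon, such as a saturated amine, a carboxylic acid on the ring or a longer alkyl chain in place of the aryl ring.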